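Swapping a side chain: from compound 1 to compound 4

The source may hold more compounds than are shown below. What is called first, only, known or untested is meant among the compounds shown, and "the series" means these compounds.

Of the compounds shown here, three built on a shared core have been tested in a functional assay on the whole organism (Tail, strain ICR) with Mus musculus as the target, in the tail flick test, with a stated time of 60 min, at a dose of 25 umol/kg by the oral route; a lower number here means a weaker effect, a higher number a stronger effect of the compound at the dose given. Compound 1 `NC(=O)CC[C@H](NC(=O)CN(c1ncnc2c1ncn2C1CCCCO1)C1CC1)C(=O)OCc1ccccc1` gives 39.4%. Compound 2 `C[C@H](NC(=O)CN(c1nc(Cl)nc2[nH]cnc12)C1CC1)C(=O)OCc1ccccc1` gives 64.3%, and compound 3 `CC(C)C[C@H](NC(=O)CN(c1nc(Cl)nc2[nH]cnc12)C1CC1)C(=O)O` gives 36.4%. Among these three numbers compound 1 stands second highest: its value and that of compound 3 lie within the usual scatter of each other, while the value of compound 2 lies beyond that scatter, above compound 1. No two of the measured compounds differ in only one place, so no single structural step can be read off directly from them.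

Compound 4 `CC(C)[C@H](NC(=O)CN(c1ncnc2c1ncn2C1CCCCO1)C1CC1)C(=O)OCc1ccccc1` has not yet been measured. It differs from compound 1 in one place: isopropyl in place of 2-carbamoylethyl on a saturated chain carbon bound to an amide-type nitrogen and a carbonyl carbon. Going by the values given here, nothing among the measured compounds isolates this kind of change, so the step of a number 5.6 percentage points higher from compound 1 to compound 4 (within the scatter) is expected to be modest and not clearly beyond the scatter in either direction. Compound 4 is therefore estimated to give 45%, with a plausible range from 22% to 68%.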

Compound 4, a percentage reported as activity, at one dose (the size of the read-out at that dose, not a potency): 34.9%
Estimate against measurement, compound 4: 10.1 percentage points above; the measured number falls inside the stated range.
By their numbers in this assay, from the lowest: compounds 4, 3 and 1 (each within the scatter of the next); then compound 2.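

Going by these compounds alone, this is the first comparison in the set that isolates one structural change. In this assay, exchanging the 2-carbamoylethyl side chain for isopropyl gives a number 4.5 percentage points lower from compound 1 to compound 4 (within the scatter). The departing side chain has a hydrogen-bond donor and a hydrogen-bond acceptor and the entering one has neither, yet this swap does not separate the two compounds at the dose tested, and no available measurement explains that result.

Going by these compounds, whether an amine, a carboxylic acid or a longer chain in the same place would shift the number beyond the scatter remains open. Also open, on these data alone, is whether the same swap would read alike on the core of compound 2.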